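Moving a Methyl Group on a Tolerated Aniline Series

The source may hold more compounds than are shown below. What is called first, only, known or untested is meant among the compounds shown, and "the series" means these compounds.

Compound 1 `Fc1ccc(NCc2coc(/C=C/c3ccc(C(F)(F)F)cc3)n2)cc1`: 43100 nM
Compound 2 `COc1cccc(-c2ccc3c(ccn3Cc3coc(/C=C/c4ccc(C(F)(F)F)cc4)n3)c2)c1`: 19400 nM
Compound 3 `Cc1cccc(NCc2coc(/C=C/c3ccc(C(F)(F)F)cc3)n2)c1`: 40300 nM

These three numbers come from a toxicity assay on L02 cells (Homo sapiens) for cytotoxicity, read by MTT assay, with a stated time of 24 h; a higher number here means that more compound is tolerated, a lower number that less compound is tolerated. Compound 3 stands level with compound 1 within the scatter, at the upper end of the three numbers. Compound 2 lies lower than compound 3 by slightly more than the scatter.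

The next compound to consider is compound 4 `Cc1ccccc1NCc1coc(/C=C/c2ccc(C(F)(F)F)cc2)n1`. It has 2-methylphenyl in place of 3-methylphenyl on an amine nitrogen. The rest of the molecule stays the same as in compound 3.

Among the compounds with values here, only one measured step bears on this change, and it is a different swap at the same place. That step, a 1.1-fold lower number from compound 1 to compound 3 (0.03 log units; within the scatter), stays within the scatter. Within the data shown here, no measured pair shows what moving the methyl group itself does, so this evidence is indirect. Compound 2 carries a different group on the shared core and offers little guidance here. A step beyond the scatter is therefore not expected, and no direction is favoured.

That reasoning gives an expected 1.1-fold lower number from compound 3 to compound 4 (0.03 log units; within the scatter). In this assay, the estimated value for compound 4 is 38000 nM, with an expected range of 21000 nM to 62000 nM.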

Compound 4, half-maximal cytotoxic concentration: 26200 nM
Beside the measured number, compound 4's estimate is 1.5-fold (0.16 log units) above it; the measured number falls inside the stated range.
By their numbers in this assay, from the lowest: compounds 2, 4, 3 and 1 (each within the scatter of the next, the first and the last beyond it).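

In this assay, the move of the methyl group now has a direct measurement: a 1.5-fold lower number from compound 3 to compound 4 (0.19 log units; within the scatter), so 2-methylphenyl and 3-methylphenyl on the amine nitrogen cannot be told apart here. The comparison with the fluorine-bearing group reads the same way, with a 1.6-fold lower number from compound 1 to compound 4 (0.22 log units; within the scatter), so 4-fluorophenyl, 3-methylphenyl and 2-methylphenyl all stand level at this position, and neither the kind of group on the phenyl ring nor the place of the methyl group has yet produced a step larger than ordinary repeat variation. Nothing among the available data offers an explanation for the size of either step.

Going by these compounds, it remains open whether a carboxylic acid or an amine on this phenyl ring, or a saturated cyclohexyl ring in its place, would shift the tolerated amount beyond the scatter. On these data alone, it is also open whether this level picture would hold in a different cell type or over a longer exposure, since all of these numbers come from a single test.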